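A few compounds are considered here, and "the series" means these few. Any claim that something is new, unique, unknown or untested is made for them only; others in the source may bear on it.

Measured so far in a functional assay on ECa-109 cells (Homo sapiens) for cytotoxicity, read by MTT assay, with a stated time of 72 h; on this read-out lower numbers stand for stronger inhibition and higher numbers for weaker inhibition:
- compound 1 `CC(C)=C1C(=O)N(c2ccc(Cl)cc2)N(c2ccc(Cl)cc2)C1=O` gives 42100 nM
- compound 2 `O=C1C(=Cc2ccc(F)cc2)C(=O)N(c2ccc(Cl)cc2)N1c1ccc(Cl)cc1` gives 35600 nM
- compound 3 `COc1cccc(C=C2C(=O)N(c3ccc(Cl)cc3)N(c3ccc(Cl)cc3)C2=O)c1O` gives 39000 nM

Compound 3 lies within the scatter of both compound 1 and compound 2, so it stands level with them on these numbers. The next compound, not yet measured, is compound 4 `O=C1C(=Cc2ccc(F)cc2F)C(=O)N(c2ccc(Cl)cc2)N1c1ccc(Cl)cc1`. The change from compound 3 is 2,4-difluorophenyl in place of 2-hydroxy-3-methoxyphenyl on a double-bonded chain carbon bound to a double-bonded ring carbon, with 2,4-difluorophenyl in place of 2-hydroxy-3-methoxyphenyl on a double-bonded chain carbon bound to a double-bonded ring carbon.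

Going by the values given here, one measured step bears on this place: a 1.1-fold higher number from compound 2 to compound 3 (0.04 log units; within the scatter). That step exchanged 4-fluorophenyl for the group that compound 4 gives up, and it stayed within the scatter. No measurement with 2,4-difluorophenyl exists yet. No step beyond the scatter is therefore expected in this assay. The expected change is a 1.1-fold lower number from compound 3 to compound 4 (0.03 log units; within the scatter) and it stays within the scatter. For compound 4 the estimated value is 36000 nM, with an expected range from 18000 nM to 62000 nM.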

Compound 4, half-maximal inhibitory concentration: 13100 nM
The estimate for compound 4 lay 2.7-fold (0.44 log units) above the measured number, outside the stated range (below it).
By their numbers in this assay, from the lowest: compound 4; then compounds 2, 3 and 1 (each within the scatter of the next).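

In this assay, the place on a double-bonded chain carbon bound to a double-bonded ring carbon now gives its first step beyond the scatter: a 3.0-fold lower number from compound 3 to compound 4 (0.47 log units; beyond the scatter), with 2,4-difluorophenyl in place of 2-hydroxy-3-methoxyphenyl. Going by these compounds alone, the narrower comparison is a 2.7-fold lower number from compound 2 to compound 4 (0.43 log units; beyond the scatter), where the only change is fluoro in place of hydrogen on an aromatic carbon, so this place responds to a small edit even though the earlier exchange of 4-fluorophenyl for 2-hydroxy-3-methoxyphenyl stayed within the scatter. No measurement is at hand that accounts for this difference.

From the compounds shown here alone, whether a chlorophenyl group or a pyridine ring at this place would match compound 4 remains open. Also open, going by these compounds, is whether the step seen in this assay carries over to other cell lines.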